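Piperidine to Morpholine Swap Across Two Chromone Cores

This account rests on a few compounds, and the source may have more. Where it says the series, first, only, none or still open, it means among the compounds named here.

Compound 1 `COc1ccc2occ(CSC(=S)N3CCOCC3)c(=O)c2c1`: 9500 nM
Compound 2 `COc1ccc2occ(CSC(=S)N3CCCCC3)c(=O)c2c1`: 3500 nM
Compound 3 `CCOC(=O)c1cc(=O)c2cc(CSC(=S)N3CCCCC3)ccc2o1`: 5800 nM

Three dithiocarbamates were tested in a functional assay on HeLa cells (Homo sapiens) for antiproliferative activity, read by MTT assay, with a stated time of 72 h; a higher number here means a weaker inhibitor, a lower number a stronger inhibitor. Compound 2 gives 3500 nM, and compound 1 gives 9500 nM; the two differ only by morpholin-4-yl in place of piperidin-1-yl on a thiocarbonyl carbon, and that change brought a 2.7-fold higher number from compound 2 to compound 1 (0.43 log units; beyond the scatter). Compound 3 gives 5800 nM on a different core; the difference between the core of compound 3 and that of compound 2 is not broken down here, and the values of compound 3 and compound 2 lie within the usual scatter of each other, as do those of compound 3 and compound 1.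

Compound 4 `CCOC(=O)c1cc(=O)c2cc(CSC(=S)N3CCOCC3)ccc2o1` has not yet been measured in this assay. It differs from compound 3 by morpholin-4-yl in place of piperidin-1-yl on a thiocarbonyl carbon, at a place described in the same words as for compound 1 and compound 2, so it is the same change. Among the compounds with values here, the step is expected to be a 2.6-fold higher number from compound 3 to compound 4 (0.41 log units; beyond the scatter), resting on the single earlier instance, because a 2.7-fold higher number from compound 2 to compound 1 (0.43 log units; beyond the scatter) was seen on the other core. Compound 4 is therefore estimated at 15000 nM, likely between 7000 nM and 35000 nM.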

Compound 4, half-maximal inhibitory concentration: > 25000 nM
Compound 4 gave a limit, no number; the forecaster's own chance of this, stated with the estimate: 10%; middle value at least 1.6-fold (0.22 log units) away from the limit.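

In this assay, morpholin-4-yl in place of piperidin-1-yl on a thiocarbonyl carbon again gave a higher number on the second core, with an at least 4.3-fold higher number from compound 3 to compound 4 (0.63 log units; beyond the scatter), so the direction of the step carried over from the core of compound 2 to the core of compound 3. Compound 4 reached a limit of the assay, > 25000 nM, which is not a number. Whether the step is larger on one core than on the other stays unsettled, and two cores do not make a general rule for the series: the same change on two cores in this assay, a 2.7-fold higher number (0.43 log units; beyond the scatter) from compound 2 to compound 1 and an at least 4.3-fold higher number (0.63 log units; beyond the scatter) from compound 3 to compound 4; the limit leaves it open whether they differ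

The compounds shown leave open how the step would run with other amines on the thiocarbonyl carbon, such as pyrrolidin-1-yl or 4-methylpiperazin-1-yl in place of these two groups. They also leave open whether the same step would hold on the core of compound 3 if its ethyl ester gave way to a carboxylic acid or an amide.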